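Methoxy in place of chloro: compound 3 to compound 4

The compounds below may be only part of what the source reports. "The series", "measured", "known", "first", "only" and "open" are said of these compounds alone.

Three compounds of the series carry a number in a functional assay on Ehrlich cells (Mus musculus) for cytotoxicity, read by trypan blue exclusion, with a stated time of 2 h, tested at 5 ug/mL; on this read-out lower numbers stand for a stronger effect and higher numbers for a weaker effect at the one concentration tested. Compound 1 `N#Cc1c(N)[n+]([O-])c2ccc(Cl)cc2[n+]1[O-]` gives 87.8%, compound 2 `CNc1c(C#N)[n+]([O-])c2cc(Cl)ccc2[n+]1[O-]` gives 96%, and compound 3 `Cc1c(C(=O)N=[N+]=[N-])[n+]([O-])c2cc(Cl)ccc2[n+]1[O-]` gives 92.6%. Among the measured compounds shown here, the only single-place step among them, methyl in place of hydrogen on a nitrogen on an aromatic ring, is a number 8.2 percentage points higher from compound 1 to compound 2 (within the scatter). Compound 3 stands second highest of the three numbers; its value lies within the scatter of compound 2 and within the scatter of compound 1, so no order can be read among the three.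

Compound 4 `COc1ccc2c(c1)[n+]([O-])c(C(=O)N=[N+]=[N-])c(C)[n+]2[O-]` has not yet been measured in this assay. It differs from compound 3 by methoxy in place of chloro on an aromatic carbon. For the measured compounds named here, no measured step touches this position or exchanges these two groups, so nothing bears directly on it; the one step available, the methyl for hydrogen on the ring nitrogen, stayed within the scatter. With all three numbers close together and that one step flat, the step of a number 0.6 percentage points lower from compound 3 to compound 4 (within the scatter) is expected to remain within the scatter, in no particular direction. Compound 4 is therefore estimated at 92%, with an expected range from 82% to 100%.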

Compound 4, a percentage reported as activity, at one concentration (the size of the read-out at that concentration, not a potency): 81.1%
For compound 4 the middle estimate is 10.9 percentage points above the measured one; the measured number lies below the stated range.
By their numbers in this assay, from the lowest: compounds 4, 1, 3 and 2 (each within the scatter of the next, the first and the last beyond it).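

Methoxy in place of chloro on an aromatic carbon gives, in this assay, a number 11.5 percentage points lower from compound 3 to compound 4 (beyond the scatter), and this is the first single-place step in the series to lie beyond the scatter. Among the compounds shown here, the only earlier step, a number 8.2 percentage points higher from compound 1 to compound 2 (within the scatter), sat on a nitrogen, so the series now shows that an exchange on the six-membered aromatic ring of carbon only can move this read-out towards a stronger effect at the one concentration tested, although the size of the step is modest and it rests on a single pair. Nothing shown accounts for the step, and no measurement gives a cause for it.

As far as these compounds go, whether the lower number comes from the arrival of methoxy or the loss of chloro remains open, and an amine, a hydroxy group, an ethoxy group or plain hydrogen at the same place on the shared core would help separate the two. Also open, from the compounds shown here alone, is whether the same exchange on the core of compound 2 gives a step of similar size or whether it holds only on the core of compound 3.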